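The source may hold more compounds than are shown below. What is called first, only, known or untested is meant among the compounds shown, and "the series" means these compounds.

Working notes on the series, step from compound 3 to compound 4.

Compound 3 `CC(C)[C@H](NC(=O)CN(c1nc(Cl)nc2[nH]cnc12)C1CC1)C(=O)O` gives 38.8% in a functional assay on the whole organism (Tail, strain ICR) with Mus musculus as the target, in the tail flick test, with a stated time of 60 min, at a dose of 25 umol/kg by the oral route; a lower number here means a weaker effect, a higher number a stronger effect of the compound at the dose given. Of the three compounds measured there, compound 3 holds the lowest number, but its nearest neighbour is compound 2 `O=C(O)CNC(=O)CN(c1nc(Cl)nc2[nH]cnc12)C1CC1`, which gives 38.9%, and the furthest is compound 1 `O=C(CN(c1nc(Cl)nc2[nH]cnc12)C1CC1)N[C@@H](CO)C(=O)O`, which gives 39.8%; both gaps are within the scatter, so no order among the three can be read from these values.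

Compound 4 `CSCC[C@H](NC(=O)CN(c1nc(Cl)nc2[nH]cnc12)C1CC1)C(=O)O` is the next member. The change from compound 3 is 2-(methylsulfanyl)ethyl in place of isopropyl on a saturated chain carbon bound to an amide-type nitrogen and a carbonyl carbon.

The measured steps that bear on this place are those at the same saturated chain carbon. From hydrogen to isopropyl the step was a number 0.1 percentage points lower from compound 2 to compound 3 (within the scatter), from hydroxymethyl to isopropyl it was a number 1 percentage points lower from compound 1 to compound 3 (within the scatter), and from hydroxymethyl to hydrogen it was a number 0.9 percentage points lower from compound 1 to compound 2 (within the scatter). None of them left the scatter, although the groups tried there differ in size and in counted acceptors. The entering 2-(methylsulfanyl)ethyl brings one more heavy atom and one acceptor than isopropyl, but no measured step gives a reason to expect a shift at this place. The estimated step of a number 0.2 percentage points higher from compound 3 to compound 4 (within the scatter) is therefore expected to stay within the scatter, in no firm direction.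

Compound 4 is expected to give about 39% in this assay, within a range from 29% to 49%.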

Compound 4, a percentage reported as activity, at one dose (the size of the read-out at that dose, not a potency): 22.8%
For compound 4 the middle estimate is 16.2 percentage points above the measured one; measured number below the stated range.
By their numbers in this assay, from the lowest: compound 4; then compounds 3, 2 and 1 (each within the scatter of the next).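

At the saturated chain carbon bound to an amide-type nitrogen and a carbonyl carbon, the read-out in this assay does depend on the group carried: 2-(methylsulfanyl)ethyl in place of isopropyl gives a number 16 percentage points lower from compound 3 to compound 4 (beyond the scatter) and in place of hydrogen gives a number 16.1 percentage points lower from compound 2 to compound 4 (beyond the scatter) while the comparison with the hydroxymethyl compound gives a number 17 percentage points lower from compound 1 to compound 4 (beyond the scatter) as its step. Hydrogen, isopropyl and hydroxymethyl could not be told apart at this place, so 2-(methylsulfanyl)ethyl is the only group shown that separates from the others, and the separation is towards a weaker effect at the dose given. Nothing available bears on why this group goes with the lower number.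

The compounds shown cannot tell whether the sulfur atom or the longer chain goes with the lower number, since a plain n-butyl chain at this place is absent from them. From the compounds shown here alone, how an amine or a carboxylic acid at the end of such a chain would read also stays open, as does whether an oxygen in place of the sulfur would give the same result.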